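The source may report more compounds than this note shows. Statements on the series, on what has been measured and on what is new or still open speak of the compounds shown alone.

Measured so far in a functional assay on CCRF-CEM cells (Homo sapiens) for inhibition, read by MTT assay, with a stated time of 2 days, tested at 10 uM; a lower number here means less inhibition, a higher number more inhibition at the concentration tested (going by the name of the read-out):
compound 1 `COC(=O)c1cc(-n2cc(-c3cc(O)ccc3O)nn2)ccc1O` gives 52%;
compound 2 `COc1cc(OC)cc(-c2cn(-c3ccc(O)c(C(=O)OCCCc4ccccc4)c3)nn2)c1` gives 8%;
compound 3 `COc1ccccc1-c1cn(-c2ccc(O)c(C(=O)OCCCc3ccccc3)c2)nn1` gives 4%.

On these numbers compound 3 stands lowest of the three, though its gap to compound 2 is within the scatter, and only compound 1 sits clearly higher. Compound 4 `O=C(OCCCc1ccccc1)c1cc(-n2cc(-c3cc(O)ccc3O)nn2)ccc1O` is not yet measured. The change to it is 2,5-dihydroxyphenyl in place of 2-methoxyphenyl on an aromatic carbon. Within the data shown here, the one measured step, a number 4 percentage points lower from compound 2 to compound 3 (within the scatter), was within the scatter and does not involve the entering group. Compound 1, which also carries the 2,5-dihydroxyphenyl, gives 52%, while compound 3 gives 4%; this pair is not a single step, so it can only suggest direction. Compound 4 is therefore expected to rise, a number 26 percentage points higher from compound 3 to compound 4 (beyond the scatter), to an estimated 30% (range 8% to 55%).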

Compound 4, a percentage reported as inhibition, at one concentration (the size of the read-out at that concentration, not a potency): 81%
Compound 4: the middle estimate sits 51 percentage points below what was measured, and the stated range ends below it.
By their numbers in this assay, from the lowest: compounds 3 and 2 (each within the scatter of the next); then compound 1; then compound 4.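

In this assay, 2,5-dihydroxyphenyl on this aromatic carbon of the five-membered ring brings a large rise, a number 77 percentage points higher from compound 3 to compound 4 (beyond the scatter), and likewise a number 73 percentage points higher from compound 2 to compound 4 (beyond the scatter), so this position responds strongly to the entering group, which the step between the two methoxy-bearing groups did not show. With the 2,5-dihydroxyphenyl kept, phenethyl in place of hydrogen on the ester chain adds a modest gain, a number 29 percentage points higher from compound 1 to compound 4 (beyond the scatter). Nothing given here accounts for these steps. The compounds shown leave open whether both hydroxyl groups are needed, which a 2-hydroxyphenyl group would test. They also leave open how an amide or a carboxylic acid in place of the ester would read.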